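Replacing naphthalen-1-yl: from compound 1 to compound 4

The source may report more compounds than this note shows. Statements on the series, on what has been measured and on what is new or still open speak of the compounds shown alone.

- Compound 1 `COc1cc(/C=C/C(=O)/C=C/c2cccc3ccccc23)ccc1OCc1cn(CCOc2cc(=O)oc3ccccc23)nn1`: 85%
- Compound 2 `COc1cc(/C=C/C(=O)/C=C/c2ccccc2)ccc1OCc1cn(CCCCOc2cc(=O)oc3ccccc23)nn1`: 31%
- Compound 3 `COc1ccc(/C=C/C(=O)/C=C/c2ccc(OCc3cn(CCCCCOc4cc(=O)oc5ccccc45)nn3)c(OC)c2)cc1`: 30%

In a functional assay on COLO 205 cells (Homo sapiens) for inhibition, read by sulforhodamine B assay, with a stated time of 48 h, tested at 50 uM (a higher number here means more inhibition of growth at the concentration tested, a lower number less inhibition of growth), compound 1 stands highest of the three at 85%, and the gaps to compound 2 and compound 3 are both beyond the scatter. Compound 2 and compound 3 lie within the scatter of each other.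

Compound 4 `COc1ccc(/C=C/C(=O)/C=C/c2ccc(OCc3cn(CCOc4cc(=O)oc5ccccc45)nn3)c(OC)c2)cc1OC` carries 3,4-dimethoxyphenyl in place of naphthalen-1-yl on a double-bonded chain carbon bound to a double-bonded chain carbon. The rest of compound 1 is kept.

For the measured compounds named here, no measured pair differs in one place only, so this change has no direct precedent. Compound 2 and compound 3 each differ from compound 1 in more than one place and give only a loose lower guide. A fall in this assay is expected, probably beyond the scatter, though its size is poorly defined. The expected change is a number 30 percentage points lower from compound 1 to compound 4 (beyond the scatter). For compound 4 the estimated value is 55%, with an expected range of 30% to 82%.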

Compound 4, percent growth inhibition at one concentration: 80%
Compound 4: middle estimate off by 25 percentage points, on the low side; low and high end bracket the measured number.
By their numbers in this assay, from the lowest: compounds 3 and 2 (each within the scatter of the next); then compounds 4 and 1 (each within the scatter of the next).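

In this assay, for the compounds shown here, the one-place comparison reads a number 5 percentage points lower from compound 1 to compound 4 (within the scatter) and is the first for this position. On a double-bonded chain carbon bound to a double-bonded chain carbon, 3,4-dimethoxyphenyl thus stands in for naphthalen-1-yl with no difference beyond the scatter, so at the single concentration tested the second aromatic ring of naphthalen-1-yl is not required, and two hydrogen-bond acceptors can enter with it. No measurement at hand accounts for the two groups reading alike.

Compound 2 and compound 3 each differ from compound 1 and compound 4 in more than one place, so their lower numbers cannot be assigned to this position or to any other single part. As far as these compounds go, how a phenyl ring carrying an amine or a carboxylic acid would read at this position remains open.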